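This account rests on a few compounds, and the source may have more. Where it says the series, first, only, none or still open, it means among the compounds named here.

Measured so far in a functional assay on Jurkat cells (Homo sapiens) for activation, with a stated time of 24 h; on this read-out higher numbers stand for an effect only at larger amounts of compound and lower numbers for an effect already at smaller amounts:
Compound 1, `Oc1ccccc1CNc1ccccc1`: "not active" (no number reported)
Compound 2, `Oc1ccccc1CNc1ccc(N2CCNCC2)cc1`: "not active" (no number reported)
Compound 3, `Cc1ccc(-c2ccc(NCc3ccccc3O)cc2)cc1`: 3790 nM

All three compounds share the same core, a phenol whose ring carbon next to the hydroxyl carries an aminomethyl link to an aniline ring; they differ only in what that aniline ring carries. For compound 1 and compound 2 this assay reports no number at all, only that no effect was seen. Compound 3 is the only entry with a measured concentration, so it stands alone on the numbers shown, and there is no measured pair from which the size of a single structural change can be read.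

Compound 4, `Oc1ccccc1CNc1ccc(-c2ccc(C(F)(F)F)cc2)cc1`, is the compound to be measured. It differs from compound 3 in one place: trifluoromethyl in place of methyl on an aromatic carbon. Going by the values given here, with no measured step to lean on, the change is small in the count of atoms and keeps the same position on the same ring, so the expected step is modest, within or near the scatter, with a slight lean toward an effect at smaller amounts. The step from compound 3 to compound 4 is estimated as a 1.5-fold lower number from compound 3 to compound 4 (0.18 log units; within the scatter). Compound 4 is therefore expected to give about 2500 nM, somewhere between 800 nM and 8000 nM.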

Compound 4, half-maximal effective concentration: "not active" (no number reported)
Compound 4 has no reported number here, and the estimate cannot be compared.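

Going by these compounds alone, compound 4 is reported as not active in this assay and carries no number, so no step from compound 3 to compound 4 can be read. Nothing shown here explains this result. The compounds shown leave open how far trifluoromethyl in place of methyl shifts this read-out; compound 3 remains the only one with a number, 3790 nM.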